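The source may hold more compounds than are shown below. What is called first, only, known or untested is meant among the compounds shown, and "the series" means these compounds.

Compound 1 `CCn1c(=O)n(-c2ccc(C#N)c(C(F)(F)F)c2)c2ccccc21` gives 3470 nM in a physicochemical assay for solubility; on this read-out lower numbers stand for lower solubility and higher numbers for higher solubility.
Compound 2 `N#Cc1ccc(-n2c(=O)n(Cc3cccnc3)c3ccccc32)cc1C(F)(F)F` gives 2500 nM in this assay.

Among these two numbers compound 2 holds the lower one, with compound 1 as its only neighbour; the step of a 1.4-fold lower number from compound 1 to compound 2 (0.14 log units; within the scatter) lies within the scatter, so no order between the two can be claimed. Compound 3 `CNC(=O)c1ccc(Cn2c(=O)n(-c3ccc(C#N)c(C(F)(F)F)c3)c3ccccc32)cc1F` has not yet been measured. It differs from compound 2 in one place: 3-fluoro-4-(methylcarbamoyl)phenyl in place of pyridin-3-yl on a saturated chain carbon bound to an aromatic nitrogen. Among the measured compounds shown here, the only measured step, a 1.4-fold lower number from compound 1 to compound 2 (0.14 log units; within the scatter), concerns the same place, where pyridin-3-yl replaced methyl, and it stayed within the scatter. For the measured compounds named here, the present change is larger in what leaves and what enters, and no measured step of the same kind exists, so its direction cannot be read from the data. The expected step is a 1.4-fold lower number from compound 2 to compound 3 (0.14 log units; within the scatter). For compound 3 the estimate in this assay is 1800 nM, with a range from 600 nM to 5500 nM.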

Compound 3, solubility: 9900 nM
For compound 3 the middle estimate is 5.5-fold (0.74 log units) below the measured one; the measured number lies above the stated range.
By their numbers in this assay, from the lowest: compounds 2 and 1 (each within the scatter of the next); then compound 3.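

Among the compounds shown here, at the position on a saturated chain carbon bound to an aromatic nitrogen, pyridin-3-yl in place of methyl had stayed within the scatter in this assay, but 3-fluoro-4-(methylcarbamoyl)phenyl brings the first steps beyond it: a 4.0-fold higher number from compound 2 to compound 3 (0.60 log units; beyond the scatter), and a 2.9-fold higher number from compound 1 to compound 3 (0.46 log units; beyond the scatter). The read-out therefore does respond to what sits at this position, and compound 3 holds the highest number of the three, with both of its steps beyond the scatter. Nothing measured for these compounds accounts for this rise.

The entering group differs from pyridin-3-yl in its ring, its fluorine and its methylcarbamoyl group all at once, so the compounds shown cannot assign the step to any one of these parts. A plain phenyl, 4-(methylcarbamoyl)phenyl without the fluorine, or a carboxylic acid in place of the methylcarbamoyl group would begin to separate them.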